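Swapping the Dichlorophenyl Amide for a Methoxyphenyl Amide

This account rests on a few compounds, and the source may have more. Where it says the series, first, only, none or still open, it means among the compounds named here.

Measured so far:
- compound 1 `CCN1CCN(c2cc(C)c3cc(NC(=O)c4cc(Cl)cc(Cl)c4)ccc3n2)CC1`: 2660 nM
- compound 2 `Cc1cc(NCCN2CCCC2)nc2ccc(NC(=O)c3ccc(Cl)c(Cl)c3)cc12`: 9530 nM
- compound 3 `Cc1cc(N2CCN(C(C)C)CC2)nc2ccc(NC(=O)c3ccc(Cl)c(Cl)c3)cc12`: 6680 nM

All three were tested in a functional assay on SK-BR-3 cells (Homo sapiens) for antiproliferative activity, read by MTT assay, with a stated time of 72 h; on this read-out higher numbers stand for weaker inhibition and lower numbers for stronger inhibition. Among them compound 1 stands lowest, with compound 3 the nearest and compound 2 the furthest; both of those gaps lie beyond the scatter. Within the data shown here, the one step that can be followed between measured compounds, a 1.4-fold lower number from compound 2 to compound 3 (0.15 log units; within the scatter), changes the group at the other end of the shared core and stays within the scatter.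

Compound 4 `CCN1CCN(c2cc(C)c3cc(NC(=O)c4ccc(OC)cc4)ccc3n2)CC1` has not been measured yet. It differs from compound 1 in one place: 4-methoxyphenyl in place of 3,5-dichlorophenyl on a carbonyl carbon. Among the measured compounds shown here, no measured step touches this amide end of the molecule, so nothing already in hand says how large a change to expect in this assay, or in which direction. For the measured compounds named here, the only anchor is compound 1 itself, whose value of 2660 nM is the starting point. On that basis the estimate for compound 4 is 5000 nM, expected to fall between 1500 nM and 20000 nM. That means an expected step of a 1.9-fold higher number from compound 1 to compound 4 (0.27 log units; within the scatter), a guess with a wide range rather than a prediction resting on evidence.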

Compound 4, half-maximal inhibitory concentration: 9000 nM
For compound 4 the middle estimate is 1.8-fold (0.26 log units) below the measured one; low and high end bracket the measured number.
By their numbers in this assay, from the lowest: compound 1; then compounds 3, 4 and 2 (each within the scatter of the next).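

In this assay, among these compounds, the amide end proves to be a position that matters: with the rest of compound 1 kept as it is, 4-methoxyphenyl in place of 3,5-dichlorophenyl on a carbonyl carbon gives a 3.4-fold higher number from compound 1 to compound 4 (0.53 log units; beyond the scatter) and is the first step followed here to go beyond the scatter, as the only earlier one, at the other end of the shared core, stayed within it. Both groups hold 8 heavy atoms and one six-membered aromatic ring, so the difference lies in what that ring carries: the chlorine atoms leave, and a methoxy group, which counts as a hydrogen-bond acceptor, enters. Nothing measured here explains why the number rises with this change.

This single step changes the kind of substituent and its place on the ring together, so a plain phenyl ring or a 4-chlorophenyl group on the same carbonyl carbon would be needed to tell whether losing the chlorine atoms or gaining the methoxy group counts for more. Also open, going by these compounds, is whether the same swap would have a similar effect with the other end groups carried by compound 2 and compound 3.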